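A few compounds are considered here, and "the series" means these few. Any claim that something is new, unique, unknown or untested is made for them only; others in the source may bear on it.

Series notes, a functional assay on MCF7 cells (Homo sapiens) for inhibition, read by sulforhodamine B assay, with a stated time of 48 h; a higher number here means a weaker inhibitor, a lower number a stronger inhibitor:
Compound 1 `COc1cc(COC(c2ccc(OC)c(OC)c2OC)c2cccc3ccccc23)cc(OC)c1` gives > 20000 nM, a limit of the assay only.
Compound 2 `C=CCOC(c1ccc(OC)c(OC)c1OC)c1cccc2ccccc12` gives > 20000 nM, again only a limit.
Compound 3 `COc1ccc(C(OCc2ccc(C)cc2)c2cccc3ccccc23)c(OC)c1OC` gives 10700 nM.

Within the data shown here, compound 3 is the only member with a number; the two others sit at the limit (the limit of > 20000 nM in this assay, at which 2 of the 3 values shown sit). Compound 4 `COC(=O)c1ccc(COC(c2ccc(OC)c(OC)c2OC)c2cccc3ccccc23)cc1` differs from compound 3 by methoxycarbonyl in place of methyl on an aromatic carbon. Among the measured compounds shown here, no measured step alters a substituent on that ring; the two steps that reach compound 3, an at least 1.8-fold lower number from compound 1 to compound 3 (0.27 log units; that floor lies within the scatter) and an at least 1.8-fold lower number from compound 2 to compound 3 (0.27 log units; that floor lies within the scatter), exchange the whole group on the saturated chain carbon bound to oxygen, and each only sets a floor that lies within the scatter. In this assay no step beyond the scatter is therefore expected for compound 4, and the step of a 1.1-fold higher number from compound 3 to compound 4 (0.05 log units; within the scatter) is the estimate. Compound 4 is expected at 12000 nM, between 4000 nM and 40000 nM.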

Compound 4, half-maximal inhibitory concentration: > 20000 nM
Compound 4 gave a limit, no number (the forecaster's own chance of this, stated with the estimate: 35%); at least 1.6-fold (0.22 log units) between middle value and limit.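

In this assay, among these compounds, only this step alters a substituent on the ring rather than exchanging the whole group: methoxycarbonyl in place of methyl gives an at least 1.8-fold higher number from compound 3 to compound 4 (0.27 log units; that floor lies within the scatter) and so sets only a floor, with no real loss established. Methyl remains the only substituent at this position with a number, and the steps from compound 1 and compound 2 to compound 4 cannot be read. The series now gathers at one limit: the limit of > 20000 nM in this assay, at which 3 of the 4 values shown sit.

From the compounds shown here alone, how large the step from methyl to methoxycarbonyl really is stays open. Going by these compounds, whether a carboxylic acid or an amine at this ring position would give a number also stays open.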